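Extending the amine of compound 2 by an ethyl

The source may report more compounds than this note shows. Statements on the series, on what has been measured and on what is new or still open speak of the compounds shown alone.

Compound 2 `CN(C)CC(O)COc1ccccc1C(=O)CCc1ccccc1` is the weaker of the two measured compounds: in a functional assay on CCRF-CEM/VCR-1000 cells (Homo sapiens) for inhibition (a lower number here means a stronger inhibitor, a higher number a weaker inhibitor), compound 2 gives 2640 nM, the highest of the two numbers shown. Among the compounds with values here, its nearest neighbour is compound 1 `O=C(CCc1ccccc1)c1ccccc1OCC(O)CNC1CCCCC1`, which in this assay gives 340 nM; the only recorded step, a 7.8-fold higher number from compound 1 to compound 2 (0.89 log units; beyond the scatter), traces the exchange of cyclohexylamino for dimethylamino on a saturated chain carbon, two bonds along the chain from an oxygen on a saturated carbon.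

Compound 3 `CCCN(C)CC(O)COc1ccccc1C(=O)CCc1ccccc1` differs from compound 2 by ethyl in place of hydrogen on a saturated chain carbon bound to an amine nitrogen, so that dimethylamino becomes methyl(propyl)amino. Within the data shown here, the one step that bears on this change is a 7.8-fold higher number from compound 1 to compound 2 (0.89 log units; beyond the scatter): the larger amine substituent of compound 1 went with the lower number. Compound 3 moves only part of the way back from dimethylamino toward a larger substituent, so the expected step of a 1.8-fold lower number from compound 2 to compound 3 (0.25 log units; within the scatter) is a modest lowering that may not clear the scatter. Compound 3 is therefore estimated at 1500 nM in this assay, with a range from 600 nM to 4000 nM.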

Compound 3, half-maximal inhibitory concentration: 490 nM
The estimate for compound 3 lay 3.1-fold (0.49 log units) above the measured number; the measured number lies below the stated range.
By their numbers in this assay, from the lowest: compounds 1 and 3 (each within the scatter of the next); then compound 2.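

In this assay, ethyl in place of hydrogen on a saturated chain carbon bound to an amine nitrogen gives a 5.4-fold lower number from compound 2 to compound 3 (0.73 log units; beyond the scatter), so turning dimethylamino into methyl(propyl)amino is by itself enough to produce a step beyond the scatter. Methyl(propyl)amino in place of cyclohexylamino gives a 1.4-fold higher number from compound 1 to compound 3 (0.16 log units; within the scatter), which lies within the scatter, so in this pair an open chain on the amine nitrogen, with no ring, does not separate from the cyclohexylamino compound, something the earlier pair of compounds could not show. No measurement available here accounts for either step.

The compounds shown leave open whether the number keeps falling as the chain on the amine nitrogen grows, for instance with butyl in place of propyl, or whether it levels off at about the range of compound 1 and compound 3. They also leave open whether propylamino, without the methyl on the nitrogen, or a piperidine, with the nitrogen held in a ring, would fall with those two compounds or nearer to compound 2.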